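Removing a Methyl Group from a Methyltransferase Inhibitor Scaffold

A few compounds are considered here, and "the series" means these few. Any claim that something is new, unique, unknown or untested is made for them only; others in the source may bear on it.

Compound 1, `COc1ccccc1-c1nnc2sc(/C=C/c3ccco3)nn12`: 62%
Compound 2, `c1ccc2c(Cc3nn4c(-c5ccoc5)nnc4s3)cccc2c1`: 43%
Compound 3, `Cc1cccc(-c2nnc3sc(/C=C/c4ccco4)nn23)c1`: 66.6%

Three compounds sharing one core were tested in an assay for inhibition of histone-lysine N-methyltransferase, H3 lysine-79 specific (Homo sapiens), read by scintillation counting, with stated times of 15 min and 60 min, tested at 25 uM, in the presence of a further agent that is not named here; a lower number here means a weaker effect, a higher number a stronger effect of the compound at the concentration tested. Compound 3 gives 66.6% in this assay, the highest number of the three, but compound 1 sits within the usual scatter of it, so no order between those two can be claimed. Compound 2 lies beyond the scatter below compound 3.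

The step to the unmeasured compound 4, `C(=C/c1nn2c(-c3ccccc3)nnc2s1)\c1ccco1`, is a single change on the six-membered aromatic ring of carbon only, at the position meta to a large group: hydrogen in place of methyl on an aromatic carbon. Put another way, the 3-methylphenyl of compound 3 becomes a plain phenyl in compound 4.

For the measured compounds named here, no pair among the measured compounds differs in one place, so there is no measured step to lean on. The change is small in size, and compound 1, with a different small group on the same ring, gives 62%, close to compound 3. The step from compound 3 to compound 4 is therefore expected to be small, a number 6.6 percentage points lower from compound 3 to compound 4 (within the scatter), leaning slightly downward but likely within the scatter. Compound 4 is estimated at 60%, with a range from 45% to 75%.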

Compound 4, a percentage reported as inhibition, at one concentration (the size of the read-out at that concentration, not a potency): 79.4%
Compound 4: the middle estimate sits 19.4 percentage points below what was measured, outside the stated range (above it).
By their numbers in this assay, from the lowest: compound 2; then compounds 1 and 3 (each within the scatter of the next); then compound 4.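

In this assay, this position on the ring is sensitive to a very small edit: a number 12.8 percentage points higher from compound 3 to compound 4 (beyond the scatter), with hydrogen in place of methyl on an aromatic carbon, and that step lies beyond the scatter. Hydrogen in place of methoxy on an aromatic carbon points the same way, a number 17.4 percentage points higher from compound 1 to compound 4 (beyond the scatter), so the plain phenyl of compound 4 reads higher than either of the two compounds that carry a small group on this ring, and neither of those two goes against this. Nothing measured alongside these numbers speaks to why the bare ring gives the stronger effect.

From the compounds shown here alone, whether this holds for groups beyond methyl and methoxy, such as a fluorine, a chlorine, an amine or a longer chain like propyl, remains open, as does what a group placed elsewhere on the ring would do. Each number is also a reading at a single concentration, so it shows the size of the effect there: compound 4 gives a stronger effect than compound 3 at that concentration, and how the two compare at any other concentration has yet to be established.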